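Chain lengthening from compound 2: outlook for compound 3

The compounds below may be only part of what the source reports. "The series", "measured", "known", "first", "only" and "open" are said of these compounds alone.

Measured so far:
compound 1 `CCCC/C=C(\C)c1c(C)cc(C)c2[n+]1CC(C)CC2` — 360 nM
compound 2 `CC/C=C/c1c(C)cc(C)c2[n+]1CC(C)C=C2` — 2000 nM

In a functional assay on HeLa S3 cells (Homo sapiens) for cytotoxicity, read by MTT assay, with a stated time of 48 h (a lower number here means a stronger inhibitor, a higher number a weaker inhibitor), compound 2 gives 2000 nM, the higher of the two numbers shown; compound 1 gives 360 nM, lower by more than the usual scatter. Compound 3 `CCCCCCCCCC/C=C/c1c(C)cc(C)c2[n+]1CC(C)C=C2` differs from compound 2 by octyl in place of hydrogen on a saturated chain carbon, two bonds along the chain from a double-bonded chain carbon. Among the measured compounds shown here, no step between measured compounds tracks this change, so the direction rests on the two values alone. A moderate fall is expected in a 2.9-fold lower number from compound 2 to compound 3 (0.46 log units; beyond the scatter) because compound 1 gives 360 nM. For compound 3 the estimate is 700 nM, within 200 nM to 3000 nM.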

Compound 3, half-maximal inhibitory concentration: 52 nM
Beside the measured number, compound 3's estimate is 13-fold (1.13 log units) above it; measured number outside the range, below it.
By their numbers in this assay, from the lowest: compound 3; then compound 1; then compound 2.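

Octyl in place of hydrogen on a saturated chain carbon, two bonds along the chain from a double-bonded chain carbon, gives in this assay a 38-fold lower number from compound 2 to compound 3 (1.59 log units; beyond the scatter). This is the only single-place step shown, and it establishes that this position accepts octyl and that the number falls sharply with it. Nothing available accounts for the size of this step. Open, from the compounds shown here alone, is how the number responds to a shorter chain such as butyl or a longer chain such as dodecyl at this position. Also open, going by these compounds, is whether an amine or a carboxylic acid there keeps any of the gain.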